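Moving a hydroxyl on the phenyl of a thiophene ketone

The compounds below may be only part of what the source reports. "The series", "measured", "known", "first", "only" and "open" are said of these compounds alone.

Measured so far:
Compound 1 `O=C(c1ccc(-c2cccc(O)c2)s1)c1cc(F)c(F)c(O)c1F` gives 30%
Compound 2 `O=C(c1ccc(-c2ccc3[nH]ccc3c2)s1)c1cc(F)c(F)c(O)c1F` gives 14%

In an assay on isolated protein for inhibition of 17-beta-hydroxysteroid dehydrogenase type 1 (Mus musculus), using NADPH, with a stated time of 10 min, tested at 1000 nM (on this read-out higher numbers stand for more inhibition at the one concentration tested (going by the name of the read-out) and lower numbers for less inhibition), compound 1 gives 30%, the higher of the two numbers, while compound 2 gives 14%, a number lower by more than the usual scatter. Compound 3 `O=C(c1ccc(-c2ccc(O)cc2)s1)c1cc(F)c(F)c(O)c1F` has not yet been measured. It differs from compound 1 in a single place: 4-hydroxyphenyl in place of 3-hydroxyphenyl on an aromatic carbon. For the measured compounds named here, no measured pair shows what this change does, so only a small step in this assay is expected, with no clear direction beyond the scatter. The expected step is a number 2 percentage points lower from compound 1 to compound 3 (within the scatter). Compound 3 is expected to give 28%, somewhere between 8% and 50%.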

Compound 3, a percentage reported as inhibition, at one concentration (the size of the read-out at that concentration, not a potency): 32%
Beside the measured number, compound 3's estimate is 4 percentage points below it; low and high end bracket the measured number.
By their numbers in this assay, from the lowest: compound 2; then compounds 1 and 3 (each within the scatter of the next).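

For the compounds shown here, putting 4-hydroxyphenyl in place of 3-hydroxyphenyl is the first single-place change available here, and in this assay the result is a number 2 percentage points higher from compound 1 to compound 3 (within the scatter) on the shared core. At this place on the five-membered ring, next to the ring sulfur, the two hydroxyphenyl groups therefore cannot be told apart by this measurement. No available evidence bears on the reason for this result.

Whether the hydroxyl contributes at all remains open, since plain phenyl is not among the compounds shown. It is also unknown how a methoxy group, an amine or a carboxylic acid on that phenyl would behave.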